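Cyclopropyl Amide Replaces the Valine Acid in a Pyridine Acrylamide

A few compounds are considered here, and "the series" means these few. Any claim that something is new, unique, unknown or untested is made for them only; others in the source may bear on it.

In an assay on a protein complex for inhibition of CDK8/Cyclin C (Homo sapiens), with a stated time of 1 h (a higher number here means a weaker inhibitor, a lower number a stronger inhibitor), compound 1, `COC1CN(C(=O)/C=C/c2ccncc2-c2ccc3[nH]ncc3c2)C1`, gives 146 nM, and compound 3, `O=C(/C=C/c1ccncc1-c1ccc2[nH]ccc2c1)N1CCOCC1`, gives 190 nM; these two numbers lie within the scatter of each other. Compound 2, `CC(C)[C@@H](NC(=O)/C=C/c1ccncc1-c1ccc2ccccc2c1)C(=O)O`, gives "not determined" (no result reported) in this assay, so no number is available to place it. Compound 4, `O=C(/C=C/c1ccncc1-c1ccc2ccccc2c1)NC1CC1`, differs from compound 2 by one change: cyclopropyl in place of 1-carboxy-2-methylpropyl on an amide-type nitrogen. With no number for compound 2, the size and direction of the step to compound 4 in this assay cannot be stated from the data. The expectation for compound 4 rests on the two amides that were measured, because compound 1 gives 146 nM and compound 3 gives 190 nM. Compound 4 is therefore expected to give about 200 nM, within a range of 60 nM to 700 nM.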

Compound 4, half-maximal inhibitory concentration: 40.1 nM
The estimate for compound 4 lay 5.0-fold (0.70 log units) above the measured number, outside the stated range (below it).
By their numbers in this assay, from the lowest: compound 4; then compounds 1 and 3 (each within the scatter of the next).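

For the compounds shown here, compound 2 has no number in this assay, so no step to compound 4 can be read. The compounds shown leave open how much of the value of compound 4, 40.1 nM, comes from the cyclopropyl group rather than the rest of its structure. No measurement shown here explains the result.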